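The source may hold more compounds than are shown below. What is called first, only, known or untested is meant among the compounds shown, and "the series" means these compounds.

Of the compounds shown here, three have so far been tested in a functional assay on SW-620 cells (Homo sapiens) for antiproliferative activity, read by MTT assay, with a stated time of 72 h; on this read-out lower numbers stand for stronger inhibition and higher numbers for weaker inhibition. Compound 1 `O=c1nc2oc(CCCCl)c(C#CCCCCCl)c2cn1Cc1cn(-c2ccc(F)cc2)nn1` gives 69600 nM. Compound 2 `O=c1nc2oc(CCCCl)c(C#CCCCCl)c2cn1Cc1cn(-c2ccc(Cl)cc2)nn1` reaches only a limit of the assay, > 100000 nM. Compound 3 `CCCCCc1ccc(C#Cc2c(-c3ccc(CCCCC)cc3)oc3nc(=O)n(Cc4cn(Cc5ccccc5)nn4)cc23)cc1` likewise stands at a limit rather than a number, > 100000 nM, placing it at the weak end of the values shown, where (the limit of > 100000 nM in this assay, at which 2 of the 3 values shown sit). Compound 4 `CCCCCc1ccc(C#Cc2c(-c3ccc(CCCCC)cc3)oc3nc(=O)n(Cc4cn(-c5ccc(Cl)cc5)nn4)cc23)cc1` differs from compound 3 in one place: 4-chlorophenyl in place of benzyl on an aromatic nitrogen. Among the compounds with values here, no measured pair isolates this change, so its effect in this assay is unknown; compound 2, which carries the 4-chlorophenyl on the aromatic nitrogen, also sits at the limit. Compound 4 is therefore expected near 120000 nM, between 40000 nM and 400000 nM. The step that the limit leaves unreadable from compound 3 to compound 4 is expected to be nothing beyond the scatter.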

Compound 4, half-maximal inhibitory concentration: > 100000 nM
Compound 4: no number, only a limit (the forecaster's own chance of this, stated with the estimate: 70%); the middle value lies beyond the limit too.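

Within the data shown here, compound 3 and compound 4 both stand at a limit of the assay, and no step between them can be read. Going by these compounds, whether 4-chlorophenyl in place of benzyl changes the antiproliferative activity at all remains open.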